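A few compounds are considered here, and "the series" means these few. Any claim that something is new, unique, unknown or untested is made for them only; others in the source may bear on it.

Two compounds share one core and differ only in the group that carries the acidic hydrogen. Compound 1 `O=C(O)c1cc(F)c(COc2ccc(Cl)c(Cl)c2)cc1F` bears a carboxy group on an aromatic carbon; in a physicochemical assay for acid dissociation, read by capillary electrophoresis, compound 1 gives 3.1. Compound 2 `CC(=O)NS(=O)(=O)c1cc(F)c(COc2ccc(Cl)c(Cl)c2)cc1F` carries acetylsulfamoyl in that place, and in this assay compound 2 gives 3.7. Going by the values given here, of the two numbers, compound 1 has the lowest, and the single measured step, a number 0.60 log units higher from compound 1 to compound 2 (beyond the scatter), shows that exchanging the carboxy group for a larger acidic group moved the value upward by a modest amount.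

Compound 3 `O=c1[nH]c(-c2cc(F)c(COc3ccc(Cl)c(Cl)c3)cc2F)no1` is not yet measured. It differs from compound 1 in this way: a group of 6 heavy atoms (2 carbon, 2 nitrogen, 2 oxygen; one five-membered aromatic ring with 3 hetero atoms) in place of a group of 3 heavy atoms (1 carbon, 2 oxygen; no ring), on an aromatic carbon. Among the compounds with values here, the only step that bears on this change is a number 0.60 log units higher from compound 1 to compound 2 (beyond the scatter); it points upward, and the new group of compound 3 departs further from carboxy than acetylsulfamoyl does, so a larger upward step is expected. Compound 3 is therefore expected to give about 5.8 in this assay, most likely between 4.8 and 6.8. That estimate means a step of a number 2.70 log units higher from compound 1 to compound 3 (beyond the scatter), expected to lie well beyond the scatter.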

Compound 3, acid dissociation constant: 4.3
Compound 3: the middle estimate sits 1.50 log units above what was measured; measured number below the stated range.
By their numbers in this assay, from the lowest: compound 1; then compound 2; then compound 3.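

In this assay, the step of a number 1.20 log units higher from compound 1 to compound 3 (beyond the scatter) shows that this aromatic carbon can carry a ring in place of an open-chain group and that the read-out then moves further than it did with acetylsulfamoyl. The ring group also stands apart from acetylsulfamoyl, with a number 0.60 log units higher from compound 2 to compound 3 (beyond the scatter), so the three groups now fall into a clear order: the group of 6 heavy atoms gives the highest number, acetylsulfamoyl comes next, and carboxy, with 3 heavy atoms, gives the lowest. No measurement shown here offers an explanation for this order.

Going by these compounds alone, with only three groups compared at this one position, it remains open where a tetrazole ring, a hydroxamic acid or a plain sulfonamide would fall in this order. On these data alone, it is also open whether the same order would hold on a core with hydrogen in place of the fluoro groups, since all three compounds carry them in the same places.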